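The source may hold more compounds than are shown below. What is called first, only, known or untested is meant among the compounds shown, and "the series" means these compounds.

Measured so far in a functional assay, with a stated time of 150 min; on this read-out lower numbers stand for stronger inhibition and higher numbers for weaker inhibition:
Compound 1 `CCOC(=O)c1cnn(-c2nc(-c3ccccc3O)c(C#N)c(=O)n2C)c1N` gives 64 ug/mL.
Compound 2 `Cn1c(NN)nc(-c2ccccc2O)c(C#N)c1=O` gives 46 ug/mL.
Compound 3 `CCOC(=O)c1cnn(-c2nc(-c3ccccc3Cl)c(C#N)c(=O)n2C)c1N` gives 93 ug/mL.

Compound 1 and compound 3 share one core and differ in a single place, (chloro in place of hydroxy on an aromatic carbon). That change gave a 1.5-fold higher number from compound 1 to compound 3 (0.16 log units; within the scatter). Compound 2 has a different core; how its core differs from that of compound 1 is not broken down here.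

Compound 4 `Cn1c(NN)nc(-c2ccccc2Cl)c(C#N)c1=O` is built from compound 2 by the same change, (chloro in place of hydroxy on an aromatic carbon). Since the place is described in the same words in both cases, it is taken as the same change. Among the compounds with values here, compound 4 is expected to show a step of a 1.5-fold higher number from compound 2 to compound 4 (0.18 log units; within the scatter) in this assay, because the only measured example of this change, a 1.5-fold higher number from compound 1 to compound 3 (0.16 log units; within the scatter), was small. For compound 4 the estimated value is 69 ug/mL, expected to fall between 35 ug/mL and 140 ug/mL.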

Compound 4, half-maximal inhibitory concentration: 62 ug/mL
Compound 4: middle estimate off by 1.1-fold (0.05 log units), on the high side, within the range that was stated.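

In this assay, chloro in place of hydroxy on an aromatic carbon gave a 1.3-fold higher number from compound 2 to compound 4 (0.13 log units; within the scatter), so the step stayed small on this second core too. The two cores agree on this change: the same change on two cores in this assay, a 1.5-fold higher number (0.16 log units; within the scatter) from compound 1 to compound 3 and a 1.3-fold higher number (0.13 log units; within the scatter) from compound 2 to compound 4, 1.1-fold (0.03 log units) apart, within the scatter of two such steps. Within the data shown here, both steps lie within the scatter, so this shows only that the swap made little measurable difference on these two cores; it does not show that chloro and hydroxy truly differ here, or that a third core would behave the same way.

The compounds shown leave open how other groups on that aromatic carbon, such as an amine, a methoxy group or a carboxylic acid, would read. Going by these compounds, whether a change with a larger step would also carry between these cores remains open as well.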